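Trading benzyl for propynyl on the cyclobutyl substituent

A few compounds are considered here, and "the series" means these few. Any claim that something is new, unique, unknown or untested is made for them only; others in the source may bear on it.

Compound 1 `O=C(O)c1csc(SCCN2C(=O)OC[C@@H]2/C=C/[C@@H](O)C2(CCc3ccccc3)CCC2)n1` is one of three compounds sharing a common core that were measured in an assay on isolated protein for binding affinity to prostaglandin E2 receptor EP1 subtype (Homo sapiens); on this read-out lower numbers stand for stronger inhibition and higher numbers for weaker inhibition. In this assay compound 1 gives 802 nM, the highest of the three numbers. Compound 2 `CC(C)(CCCCF)[C@H](O)/C=C/[C@H]1COC(=O)N1CCSc1nc(C(=O)O)cs1` gives 431 nM, and compound 3 `CCCCC1([C@H](O)/C=C/[C@H]2COC(=O)N2CCSc2nc(C(=O)O)cs2)CCC1` gives 220 nM. The gap from compound 1 to compound 2 is within the scatter, while a 3.6-fold lower number from compound 1 to compound 3 (0.56 log units; beyond the scatter) is beyond it, and a 2.0-fold lower number from compound 2 to compound 3 (0.29 log units; within the scatter) stays within the scatter.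

Compound 4 `CC#CCC1([C@H](O)/C=C/[C@H]2COC(=O)N2CCSc2nc(C(=O)O)cs2)CCC1` has not yet been measured. Its difference from compound 1 is prop-1-yn-1-yl in place of benzyl on a saturated chain carbon bound to a saturated ring carbon. For the measured compounds named here, the only measured step that bears directly on this change is a 3.6-fold lower number from compound 1 to compound 3 (0.56 log units; beyond the scatter), where the phenyl on the same chain was likewise removed and a plain chain remained; that step was modest but beyond the scatter. Going by the values given here, the change to compound 4 also removes the aromatic ring, leaving a three-carbon chain with a triple bond in its place, so a comparable downward step is expected, though the triple bond has no precedent among the measured compounds and widens the uncertainty.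

Compound 4 is therefore estimated at 300 nM, with a range from 120 nM to 750 nM, which means an expected step of a 2.7-fold lower number from compound 1 to compound 4 (0.43 log units; beyond the scatter).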

Compound 4, inhibition constant: 89 nM
For compound 4 the middle estimate is 3.4-fold (0.53 log units) above the measured one, outside the stated range (below it).
By their numbers in this assay, from the lowest: compound 4; then compounds 3, 2 and 1 (each within the scatter of the next, the first and the last beyond it).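

The triple bond now has a reading of its own: in this assay, prop-1-yn-1-yl in place of propyl gives a 2.5-fold lower number from compound 3 to compound 4 (0.39 log units; beyond the scatter) on the same chain, so the gain seen on losing the phenyl in a 3.6-fold lower number from compound 1 to compound 3 (0.56 log units; beyond the scatter) was not the whole of what this position allows. Taken from the benzyl of the first compound, the change amounts to a 9.0-fold lower number from compound 1 to compound 4 (0.95 log units; beyond the scatter) in all, and compound 4 also separates from the fluorinated chain, with a 4.8-fold lower number from compound 2 to compound 4 (0.69 log units; beyond the scatter) where the 1-butylcyclobutyl group of compound 3 gave only a 2.0-fold lower number from compound 2 to compound 3 (0.29 log units; within the scatter) and stayed within the scatter. Nothing available here accounts for the effect of the triple bond on these numbers.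

The compounds shown hold a single triple-bonded group, so it stays open whether a longer chain such as pent-2-yn-1-yl, or a nitrile at the chain end, would keep these numbers. On these data alone, it also stays open whether prop-1-yn-1-yl would give a similar step on the dimethyl-bearing carbon of compound 2, in place of the cyclobutyl ring.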